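This account rests on a few compounds, and the source may have more. Where it says the series, first, only, none or still open, it means among the compounds named here.

Measured in an ADME assay on microsomes from liver (Homo sapiens) for metabolic stability; on this read-out lower numbers stand for slow clearance and higher numbers for fast clearance:
Compound 1 `CC(NC(=O)Cn1nnc2ccccc2c1=O)c1ccc(Cl)cc1`: < 9.9 mL/min/kg
Compound 2 `C[C@H](NC(=O)Cn1nnc2ccccc2c1=O)c1ccc(Cl)cc1`: < 9.9 mL/min/kg

Both entries are limits of the assay rather than numbers, as the limit of < 9.9 mL/min/kg in this assay, at which 2 of the 2 values shown sit, shows. Compound 2 therefore stands only at its limit of < 9.9 mL/min/kg. Moving to compound 3 `C[C@@H](NC(=O)Cn1nnc2ccccc2c1=O)c1ccc(Cl)cc1` alters configuration alone: the two compounds have the same atoms and bonds and differ only in configuration as drawn: 1 of 1 stereo elements differ; a stereocentre at a saturated chain carbon is drawn S in compound 2 and R in compound 3. For the measured compounds named here, the one measured step, a step that the two limits leave unreadable from compound 1 to compound 2, bears on this change, but its size cannot be read. Compound 1, drawn without a configuration, also has a limit, < 9.9 mL/min/kg, so clearance near that limit is expected for compound 3. The expected step is a number no lower from compound 2 to compound 3 (the limit leaves the size open), with no change beyond the scatter in either direction. Compound 3 is estimated at 9.9 mL/min/kg, with an expected range from 5 mL/min/kg to 20 mL/min/kg.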

Compound 3, clearance: < 9.9 mL/min/kg
Compound 3 was reported as a limit; the forecaster's own chance of this, stated with the estimate: 65%; the middle value sits exactly at the limit.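

Compound 3 is reported as a limit, like compound 1 and compound 2, so no step among these three compounds can be read in this assay. Going by these compounds, whether the drawn configuration of compound 2 and compound 3 affects clearance at all remains open.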